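The source may hold more compounds than are shown below. What is called first, only, known or untested is meant among the compounds shown, and "the series" means these compounds.

In a functional assay on PBMC cells (Homo sapiens) for inhibition, read by HTRF, with stated times of 15 min and 24 h (on this read-out lower numbers stand for stronger inhibition and higher numbers for weaker inhibition), compound 1 `O=C(Nc1ccc2c(c1)B(O)OC2)c1ccccc1` gives > 100000 nM, which is a limit of the assay and not a number. Compound 2 `O=C(Nc1ccc2c(c1)B(O)OC2)c1ccccc1OC(F)(F)F`, with trifluoromethoxy in place of hydrogen on an aromatic carbon, gives > 100000 nM, also a limit. That leaves a step that the two limits leave unreadable from compound 1 to compound 2, and the limit of > 100000 nM in this assay, at which 2 of the 2 values shown sit, is all the measurements show. Compound 3 `O=C(Nc1ccc2c(c1)B(O)OC2)c1ccc(C(F)(F)F)cc1` carries a different change: trifluoromethyl in place of hydrogen on an aromatic carbon. Within the data shown here, the one measured step bearing on it has no readable size, so no shift in either direction beyond the scatter is expected. The estimated step is a number no higher from compound 1 to compound 3 (the limit leaves the size open). For compound 3 the expected value is 100000 nM, with an estimated range from 20000 nM to 200000 nM.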

Compound 3, half-maximal inhibitory concentration: > 100000 nM
Compound 3 was reported as a limit; the forecaster's own chance of this, stated with the estimate: 70%; the middle value lies on the limit itself.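

Among these compounds, compound 3 gives > 100000 nM in this assay, again a limit and not a number, so no step from compound 1 can be read. The compounds shown leave open whether trifluoromethyl or trifluoromethoxy shifts inhibition at all.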